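Adding two chlorines to the phenyl of compound 2

A few compounds are considered here, and "the series" means these few. Any claim that something is new, unique, unknown or untested is made for them only; others in the source may bear on it.

Measured so far in a functional assay on HepG2 cells (Homo sapiens) for cytotoxicity, read by MTT assay, with a stated time of 72 h (a higher number here means a weaker inhibitor, a lower number a stronger inhibitor), are two compounds:
compound 1 `CNC(=O)c1cc(Oc2ccc(C(=O)/C=C/c3ccc(F)cc3Cl)cc2)ccn1` with 7320 nM
compound 2 `CNC(=O)c1cc(Oc2ccc(C(=O)/C=C/c3ccccc3)cc2)ccn1` with 6640 nM

Among the compounds with values here, compound 2 stands level with compound 1, the only other compound measured, since a 1.1-fold lower number from compound 1 to compound 2 (0.04 log units; within the scatter) stays within the scatter. Next comes compound 3 `CNC(=O)c1cc(Oc2ccc(C(=O)/C=C/c3cccc(Cl)c3Cl)cc2)ccn1`, and its change from compound 2 is 2,3-dichlorophenyl in place of phenyl on a double-bonded chain carbon bound to a double-bonded chain carbon with 2,3-dichlorophenyl in place of phenyl on a double-bonded chain carbon bound to a double-bonded chain carbon. Within the data shown here, one measured step bears on this, at the same place: phenyl replacing 2-chloro-4-fluorophenyl gave a 1.1-fold lower number from compound 1 to compound 2 (0.04 log units; within the scatter) in this assay and so no step beyond the scatter is expected. Estimated here is a 1.0-fold lower number from compound 2 to compound 3 (0.00 log units; within the scatter) as the expected step. For compound 3 the expected value is 6600 nM with 3500 nM to 12000 nM as the estimated range.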

Compound 3, half-maximal inhibitory concentration: > 50000 nM
Compound 3: no number, only a limit (the forecaster's own chance of this, stated with the estimate: 5%); middle value at least 7.5-fold (0.87 log units) from the limit.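

In this assay, the group at this place turns out to matter, although the earlier pair suggested otherwise: 2,3-dichlorophenyl in place of phenyl gives an at least 7.5-fold higher number from compound 2 to compound 3 (0.87 log units; beyond the scatter), and 2,3-dichlorophenyl in place of 2-chloro-4-fluorophenyl gives an at least 6.8-fold higher number from compound 1 to compound 3 (0.83 log units; beyond the scatter). Two halogens on the phenyl are not enough for such a step, as compound 1 also carries two and stays within the scatter of compound 2, so which halogens are present and where they sit counts here. Compound 3 gives no number, and both steps are minimum sizes set by its limit: the limit of > 50000 nM in this assay, at which 1 of the 3 values shown sits.

Which of the two chlorines carries the step stays open, as does how far the true value of compound 3 lies past that limit. The compounds shown also do not tell how a methoxy group or an amine on this phenyl would read.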